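Thiosemicarbazone Hydrazone Swap: Chlorophenyl to Methylphenyl Variant

The compounds below may be only part of what the source reports. "The series", "measured", "known", "first", "only" and "open" are said of these compounds alone.

Measured compounds:
- compound 1 `CC1=CC[C@@H]([C@@](C)(O)CCCC(C)(C)NC(=S)NN)CC1` — 26800 nM
- compound 2 `CC1=CC[C@@H]([C@@](C)(O)CCCC(C)(C)NC(=S)N/N=C\c2ccc(Cl)cc2)CC1` — 7580 nM

In a functional assay on PCO3 cells (Homo sapiens) for cytotoxicity, read by sulforhodamine B assay (a lower number here means a stronger inhibitor of growth, a higher number a weaker inhibitor of growth), compound 1 gives 26800 nM. Compound 2 gives 7580 nM in this assay, the lowest of the two numbers shown, and the step of a 3.5-fold lower number from compound 1 to compound 2 (0.55 log units; beyond the scatter) is modest but beyond the scatter. Compound 3 `CC1=CC[C@@H]([C@@](C)(O)CCCC(C)(C)NC(=S)N/N=C(/C)c2ccccc2)CC1` has not yet been measured. It differs from compound 2 by a group of 9 heavy atoms (8 carbon, 1 nitrogen; one six-membered aromatic ring of carbon only) in place of a group of 9 heavy atoms (7 carbon, 1 nitrogen, 1 chlorine; one six-membered aromatic ring of carbon only), on an amide-type nitrogen. Going by the values given here, only one measured step exists, from compound 1 to compound 2, and it concerns a different change: attaching the whole aromatic hydrazone group where a bare nitrogen stood. It says the hydrazone region can move the number modestly, but nothing directly about trading a chlorine on the ring for a methyl on the double-bond carbon. Given that, the expected step of a 1.3-fold higher number from compound 2 to compound 3 (0.12 log units; within the scatter) is small, likely within the usual scatter, with a slight lean toward a higher number. Compound 3 is therefore estimated at 10000 nM, with a range from 4000 nM to 25000 nM.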

Compound 3, concentration for 50% growth inhibition: 20000 nM
Estimate against measurement, compound 3: 2.0-fold (0.30 log units) below, within the range that was stated.
By their numbers in this assay, from the lowest: compound 2; then compounds 3 and 1 (each within the scatter of the next).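

Swapping one aromatic group on the amide-type nitrogen for another of the same heavy-atom count still moves the result: in this assay the change gives a 2.6-fold higher number from compound 2 to compound 3 (0.42 log units; beyond the scatter) and is beyond the scatter, so this position responds to the makeup of the group and not only to the presence of a ring. Compound 3 also sits within the scatter of the bare starting compound, with a 1.3-fold lower number from compound 1 to compound 3 (0.13 log units; within the scatter) as its step, so among these compounds the aromatic group with chlorine in compound 2 is the one that stands apart, and carrying an aromatic ring at this position does not alone lower the number. Nothing available explains the difference between the two groups.

The group that enters has one more carbon and no chlorine, so the step cannot be divided between losing the chlorine and gaining the extra carbon. On these data alone, whether the chlorine itself matters remains open, and a group keeping that chlorine together with the extra carbon, or a bromine or a methoxy group on the aromatic ring, would test this directly.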